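A few compounds are considered here, and "the series" means these few. Any claim that something is new, unique, unknown or untested is made for them only; others in the source may bear on it.

Measured so far:
compound 1 `Nc1ncnc2c1c(-c1cnc3[nH]ccc3c1)nn2CCCC(=O)NO`: > 150000 nM
compound 2 `Nc1nc2cc(-c3nn(CCCCCCCCC(=O)NO)c4ncnc(N)c34)ccc2o1`: 2980 nM

In a functional assay on HCT-116 cells (Homo sapiens) for inhibition, read by MTT assay, with a stated time of 72 h (on this read-out higher numbers stand for weaker inhibition and lower numbers for stronger inhibition), compound 1 gives only a limit, > 150000 nM. On the numbers shown compound 1 stands at the limit of > 150000 nM in this assay, at which 1 of the 2 values shown sits. Compound 2 gives 2980 nM in this assay. Among the measured compounds shown here, no single-place step links compound 2 to compound 1, and its structure differs in more than one place, so the two values show only that compound 2 has a measured number while compound 1 has none.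

Compound 3 `CNC(=O)CCCCCCCn1nc(-c2cnc3[nH]ccc3c2)c2c(N)ncnc21` is not yet measured. It differs from compound 1 by 4-(methylcarbamoyl)butyl in place of hydroxycarbamoyl on a saturated chain carbon, three bonds along the chain from an aromatic nitrogen. For the measured compounds named here, no step between measured compounds matches this change, so no measured size of effect exists for it. For compound 3 the expectation is a step of an at least 1.2-fold lower number from compound 1 to compound 3 (0.09 log units; that floor lies within the scatter) that stays within the scatter around the limit. Compound 3 is therefore estimated at 120000 nM, with a range from 25000 nM to 400000 nM, and a fair chance that only a limit is reported again.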

Compound 3, half-maximal inhibitory concentration: 6760 nM
The estimate for compound 3 lay 18-fold (1.25 log units) above the measured number; the measured number lies below the stated range.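

Replacing hydroxycarbamoyl with 4-(methylcarbamoyl)butyl, on a saturated chain carbon, three bonds along the chain from an aromatic nitrogen, gives an at least 22-fold lower number from compound 1 to compound 3 (1.34 log units; beyond the scatter) in this assay. Among the compounds shown here, this is the first single-place change read at this position, and it shows that a measured number on this core does not depend on a hydroxycarbamoyl group, since compound 3 carries none. Compound 1 gives only a limit, so the step is a bound and not a measured gap: the limit of > 150000 nM in this assay, at which 1 of the 3 values shown sits.

The change lengthens the chain and replaces its end group at once, so the compounds shown do not separate these two effects on the number. Also open, on these data alone, is how the same longer chain would read on the core of compound 3 when ended by hydroxycarbamoyl, a carboxylic acid or a primary amide.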